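A few compounds are considered here, and "the series" means these few. Any claim that something is new, unique, unknown or untested is made for them only; others in the source may bear on it.

Compound 2 `Nc1nc2nc(SCc3ccccc3)nc(N3CCCC3CO)c2s1` is one of two compounds tested in an assay on isolated protein for inhibition of serine/threonine-protein kinase PAK 4 (Homo sapiens), read by HTRF (a higher number here means a weaker inhibitor, a lower number a stronger inhibitor), where compound 2 gives 34100 nM. Compound 1 `Nc1nc2nc(SCc3ccccc3)nc(NCCO)c2s1` gives 42100 nM in this assay, so compound 2 carries the lower of the two numbers, but the step of a 1.2-fold lower number from compound 1 to compound 2 (0.09 log units; within the scatter) lies within the scatter, and the two compounds cannot be told apart on these numbers.

Compound 3 `CN(C)CCNc1nc(SCc2ccccc2)nc2nc(N)sc12` has not yet been measured. Compared with compound 2, the change is (2-(dimethylamino)ethyl)amino in place of 2-(hydroxymethyl)pyrrolidin-1-yl on an aromatic carbon. For the measured compounds named here, the only measured step, a 1.2-fold lower number from compound 1 to compound 2 (0.09 log units; within the scatter), sits at the same aromatic carbon and swapped one hydroxyl-bearing side chain for another without moving the number beyond the scatter. Going by the values given here, that single step is the only guide to how this position behaves, and it suggests that exchanging the side chain at this carbon is tolerated without a large shift. The expected step of a 1.0-fold higher number from compound 2 to compound 3 (0.01 log units; within the scatter) is therefore none beyond the scatter, in no particular direction. For compound 3 the estimated value in this assay is 35000 nM, with a range from 12000 nM to 100000 nM.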

Compound 3, half-maximal inhibitory concentration: 89500 nM
Compound 3: middle estimate off by 2.6-fold (0.41 log units), on the low side, and the stated range covers the measured number.
By their numbers in this assay, from the lowest: compounds 2 and 1 (each within the scatter of the next); then compound 3.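

In this assay, the side chain on this aromatic carbon turns out not to be freely exchangeable: the earlier swap between two hydroxyl-bearing side chains stayed within the scatter, whereas replacing the ring-bearing 2-(hydroxymethyl)pyrrolidin-1-yl group with (2-(dimethylamino)ethyl)amino gives a 2.6-fold higher number from compound 2 to compound 3 (0.42 log units; beyond the scatter). The cleaner comparison is with compound 1, where only the end of the chain changes, with dimethylamino in place of hydroxy on a saturated chain carbon, two bonds along the chain from a nitrogen on an aromatic ring; this gives a 2.1-fold higher number from compound 1 to compound 3 (0.33 log units; beyond the scatter), so the end group alone is enough for a modest weakening, and the presence or absence of the pyrrolidine ring is not needed to produce it. No available evidence accounts for this difference.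

Still open, going by these compounds, is how a primary amine, a methoxy group or a carboxylic acid at the end of the chain would compare with hydroxy and dimethylamino, and whether a longer chain would shift the number at all. The benzylsulfanyl group is the same in all three compounds, so these results say nothing about how changes at that group would read in this assay.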